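The compounds below may be only part of what the source reports. "The series", "measured", "known", "first", "only" and "open" are said of these compounds alone.

Three compounds have been measured in a functional assay on HCC827 cells (Homo sapiens) for antiproliferative activity, read by MTT assay, with a stated time of 72 h; a lower number here means a stronger inhibitor, a higher number a weaker inhibitor:

Compound 1 `CN1CCN(c2ccc(Nc3ncc4nc(Nc5ccc(F)cc5)n([C@H]5CCNC5)c4n3)cc2)CC1` gives 1220 nM.
Compound 2 `CCOC(=O)CN1CC[C@H](n2c(Nc3ccc(F)cc3)nc3cnc(Nc4ccc(N5CCN(C)CC5)cc4)nc32)C1` gives 1810 nM.
Compound 3 `CN1CCN(c2ccc(Nc3ncc4nc(Nc5ccc(F)cc5)n([C@H]5CCN(C(=O)OC(C)(C)C)C5)c4n3)cc2)CC1` gives 580 nM.

Compound 3 stands with the lowest number of the three. Its lead over compound 1 is a 2.1-fold lower number from compound 1 to compound 3 (0.32 log units; beyond the scatter), and over compound 2 it is a 3.1-fold lower number from compound 2 to compound 3 (0.49 log units; beyond the scatter), both modest but beyond the scatter. Between compound 1 and compound 2 the step is a 1.5-fold higher number from compound 1 to compound 2 (0.17 log units; within the scatter), so those two cannot be ordered.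

Compound 4 `CN1CCN(c2ccc(Nc3ncc4nc(Nc5ccc(F)cc5)n([C@H]5CCCN(C(=O)CO)C5)c4n3)cc2)CC1` differs from compound 3 in one place: 1-((hydroxymethyl)carbonyl)piperidin-3-yl in place of 1-(tert-butoxycarbonyl)pyrrolidin-3-yl on an aromatic nitrogen. Among the compounds with values here, the steps that bear on it are those from compound 1 and compound 2 to compound 3, where a tert-butoxycarbonyl on the ring nitrogen gave a modestly lower number than hydrogen or (ethoxycarbonyl)methyl. Within the data shown here, compound 4 keeps a carbonyl on that nitrogen but changes the ring to a six-membered one, a change no measured step covers. Compound 4 is therefore expected to land close to compound 3, with a step of a 1.4-fold higher number from compound 3 to compound 4 (0.14 log units; within the scatter) that may not exceed the scatter. The estimate for compound 4 in this assay is 800 nM, within 300 nM to 2500 nM.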

Compound 4, half-maximal inhibitory concentration: 1.8 nM
Compound 4: middle estimate off by 440-fold (2.65 log units), on the high side; measured number below the stated range.
By their numbers in this assay, from the lowest: compound 4; then compound 3; then compounds 1 and 2 (each within the scatter of the next).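

In this assay, within the data shown here, the group on the aromatic nitrogen of the five-membered aromatic ring can shift the number far more than the earlier compounds showed: their changes on the ring nitrogen gave modest steps at most, whereas 1-((hydroxymethyl)carbonyl)piperidin-3-yl gives a 320-fold lower number from compound 3 to compound 4 (2.51 log units; beyond the scatter) and a 680-fold lower number from compound 1 to compound 4 (2.83 log units; beyond the scatter) and a 1000-fold lower number from compound 2 to compound 4 (3.00 log units; beyond the scatter) as well. This one change joins a six-membered ring in place of a five-membered one with a (hydroxymethyl)carbonyl in place of the earlier groups on the ring nitrogen, and the compounds shown do not separate the two. No data given here account for the size of these steps.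

On these data alone, it remains open whether the ring or the acyl group carries the drop. A 1-((hydroxymethyl)carbonyl)pyrrolidin-3-yl group, a 1-(tert-butoxycarbonyl)piperidin-3-yl group or a 1-acetylpiperidin-3-yl group would speak to that.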